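Swapping the aryl group on the shared core

The source may hold more compounds than are shown below. What is called first, only, known or untested is meant among the compounds shown, and "the series" means these compounds.

Two compounds of the series have numbers in a functional assay on MKN-45 cells (Homo sapiens) for inhibition, with a stated time of 72 h; a lower number here means a stronger inhibitor, a higher number a weaker inhibitor. Compound 1 `COc1ccc(S(=O)(=O)N2CCc3cccc(-c4ccc(N(C)C)cc4)c32)cc1` gives 237 nM in this assay, the lowest of the two numbers shown. Compound 2 `COc1ccc(S(=O)(=O)N2CCc3cccc(-c4cc(OC)c(OC)c(OC)c4)c32)cc1` gives 1080 nM in this assay, a higher number than that of compound 1 and beyond the scatter of repeated measurements, so the two compounds are told apart by this assay. The pair differs in more than one place, so what the difference between them rests on cannot be read from these two values alone.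

Compound 3 `COc1ccc(S(=O)(=O)N2CCc3cccc(-c4cccs4)c32)cc1` has not yet been measured in this assay. It differs from compound 1 in one place: thiophen-2-yl in place of 4-(dimethylamino)phenyl on an aromatic carbon. The group that enters is smaller than the one that leaves and carries a five-membered ring with one hetero atom in place of a six-membered ring of carbon only with a dimethylamino substituent. Within the data shown here, no step between measured compounds reports what such a change does in this assay, so the expectation rests on compound 1 alone.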

Compound 3, half-maximal inhibitory concentration: 165 nM
Estimate against measurement, compound 3: 3.9-fold (0.60 log units) above; the measured number lies below the stated range.
By their numbers in this assay, from the lowest: compounds 3 and 1 (each within the scatter of the next); then compound 2.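

In this assay, thiophen-2-yl in place of 4-(dimethylamino)phenyl on this aromatic carbon gives a 1.4-fold lower number from compound 1 to compound 3 (0.16 log units; within the scatter), so the assay does not tell the two groups apart. Among these compounds, this is the first one-place comparison at this position, and it shows that neither a six-membered ring of carbon only nor a dimethylamino substituent is needed here for a value in this range: the smaller five-membered aromatic ring of compound 3 gives 165 nM in this assay. No independent measurement bears on this result, so the data give no account of why the two groups read alike.

What the aromatic ring itself contributes at this carbon remains open, since the compounds shown do not include a plain hydrogen, a piperidine ring, a primary amine or a carboxylic acid in this place. Also open, going by these compounds, is what the ring sulfur and the dimethylamino group each add, which furan-2-yl, thiophen-3-yl and unsubstituted phenyl on the shared core would begin to separate.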